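Adding One Carbon to the Cyclohexyl Ring

A few compounds are considered here, and "the series" means these few. Any claim that something is new, unique, unknown or untested is made for them only; others in the source may bear on it.

In a functional assay on SK-OV-3 cells (Homo sapiens) for inhibition, read by CCK-8 assay, with a stated time of 70 h (a lower number here means a stronger inhibitor, a higher number a weaker inhibitor), compound 2 `c1ccc(COc2ccc(OCCOCCNC3CCCCC3)cc2)cc1` gives 7370 nM and so stands in the middle of the three measured numbers, with compound 1 `c1ccc(COc2ccc(OCCOCCNc3ccncc3)cc2)cc1` higher at 20600 nM and compound 3 `O=[N+]([O-])c1ccccc1COc1ccc(OCCOCCNC2CCCCC2)cc1` lower at 2880 nM in this test. Compound 4 `c1ccc(COc2ccc(OCCOCCNC3CCCCCC3)cc2)cc1` differs from compound 2 in one place (cycloheptyl in place of cyclohexyl on an amine nitrogen) with cycloheptyl in place of cyclohexyl on an amine nitrogen.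

Going by the values given here, two measured steps bear on this. The closer one is a 2.8-fold lower number from compound 1 to compound 2 (0.45 log units; beyond the scatter) and it came from cyclohexyl in place of pyridin-4-yl on that same nitrogen. The other is a 2.6-fold lower number from compound 2 to compound 3 (0.41 log units; beyond the scatter) and it came from nitro in place of hydrogen on an aromatic carbon. Among the compounds with values here, both are modest, and no measured compound yet tests a second saturated ring on the nitrogen. Going from a six-membered to a seven-membered carbon ring is a smaller edit than swapping pyridin-4-yl for cyclohexyl, so only a slight shift seems likely in this assay here. The expected change is a 1.2-fold lower number from compound 2 to compound 4 (0.09 log units; within the scatter) and this estimate stays within the scatter. For compound 4 the estimated value is 6000 nM with an expected range of 2800 nM to 12000 nM until it is measured.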

Compound 4, half-maximal inhibitory concentration: 7460 nM
The estimate for compound 4 lay 1.2-fold (0.09 log units) below the measured number, within the range that was stated.
By their numbers in this assay, from the lowest: compound 3; then compounds 2 and 4 (each within the scatter of the next); then compound 1.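

Placing cycloheptyl where cyclohexyl stood on the amine nitrogen gives a 1.0-fold higher number from compound 2 to compound 4 (0.01 log units; within the scatter) in this assay, so one extra ring carbon leaves no readable mark at this position. The other comparison at this nitrogen is a 2.8-fold lower number from compound 1 to compound 4 (0.44 log units; beyond the scatter) and lies beyond the scatter, so compounds 2 and 4, with their saturated carbon rings, both give lower numbers than compound 1 with pyridin-4-yl. No measured evidence is available to explain either result.

Still open, from the compounds shown here alone, is whether this tolerance extends to a smaller ring such as cyclopentyl, to an open hexyl chain, or to a cyclohexyl ring carrying a hydroxyl group. Also open, going by these compounds, is whether the nitro group of compound 3 would lower the number in the same way when paired with cycloheptyl.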